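Removing the Phenoxy Group from Compound 3

The compounds below may be only part of what the source reports. "The series", "measured", "known", "first", "only" and "open" are said of these compounds alone.

Compound 3 `O=C(O)CCc1ccc(C#Cc2ccnc(Oc3ccccc3)c2)cc1` gives 479 nM in an in vitro functional assay on 1321-N1 cells for agonist activity at Free fatty acid receptor 1 (Homo sapiens), read by fluorescence, spectrophotometry and calcium flux; a lower number here means that less compound is needed, a higher number that more compound is needed for the effect. That is the lowest of the three numbers, though compound 1 `O=C(O)CCc1ccc(C#Cc2ccnc(F)c2)cc1` with 513 nM lies within the scatter of it, while compound 2 `O=C(O)CCc1ccc(C#Cc2cccnc2)cc1` with 6030 nM lies far beyond the scatter. Compound 4 `O=C(O)CCc1ccc(C#Cc2ccncc2)cc1` differs from compound 3 by hydrogen in place of phenoxy on an aromatic carbon. Going by the values given here, the only step that bears on this change is a 1.1-fold lower number from compound 1 to compound 3 (0.03 log units; within the scatter), which shows that swapping a small group for a large one at this place left the number unchanged. Among the compounds with values here, compound 2 is not a single-place variant of compound 3, so it offers no direct step. Removing the group altogether is therefore expected to give only a modest step, a 1.7-fold higher number from compound 3 to compound 4 (0.22 log units; within the scatter), a slightly higher number being somewhat more likely than a lower one. Compound 4 is estimated at 800 nM, within 250 nM to 2500 nM.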

Compound 4, half-maximal effective concentration: 4070 nM
Compound 4: middle estimate off by 5.1-fold (0.71 log units), on the low side; measured number outside the range, above it.
By their numbers in this assay, from the lowest: compounds 3 and 1 (each within the scatter of the next); then compounds 4 and 2 (each within the scatter of the next).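

In this assay this place turns out not to be indifferent to substitution: there is an 8.5-fold higher number from compound 3 to compound 4 (0.93 log units; beyond the scatter) and a 7.9-fold higher number from compound 1 to compound 4 (0.90 log units; beyond the scatter) so both phenoxy and fluoro go with a lower number than hydrogen, even though they do not differ from each other beyond the scatter. Without a substituent, pyridin-4-yl and pyridin-3-yl also stay within the scatter, with a 1.5-fold lower number from compound 2 to compound 4 (0.17 log units; within the scatter) as the step. Nothing at hand explains these steps. As far as these compounds go, whether an amine or a methoxy group at this place would match fluoro and phenoxy remains open.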